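Swapping Ureido for a Succinimide Ring on the Core

This account rests on a few compounds, and the source may have more. Where it says the series, first, only, none or still open, it means among the compounds named here.

Of the compounds shown here, three have been measured in a functional assay on HepG2 cells (Homo sapiens) for inhibition, read by sulforhodamine B assay, with a stated time of 24 h; on this read-out lower numbers stand for stronger inhibition and higher numbers for weaker inhibition. Compound 1 `Nc1ncnc2c1c(-c1ccccc1)cn2-c1ccc(S(=O)(=O)Nc2ccccn2)cc1` gives 4090 nM. Compound 2 `N#Cc1c(-c2ccccc2)cn(-c2ccc(S(=O)(=O)Nc3nccs3)cc2)c1NC(N)=O` gives 4020 nM, and compound 3 `N#Cc1c(-c2ccccc2)cn(-c2ccc(S(=O)(=O)Nc3ccccn3)cc2)c1NC(N)=O` gives 4120 nM. Compound 2 has the lowest of the three numbers, but its distances to compound 1 and to compound 3 are both within the scatter, so the three results cannot be told apart.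

Going by the values given here, the only single-point step recorded so far is a 1.0-fold higher number from compound 2 to compound 3 (0.01 log units; within the scatter), which shows that exchanging the ring on the sulfonamide nitrogen left the result unchanged.

Compound 4 `N#Cc1c(-c2ccccc2)cn(-c2ccc(S(=O)(=O)Nc3nccs3)cc2)c1N1C(=O)CCC1=O` is not yet measured. It differs from compound 2 by 2,5-dioxopyrrolidin-1-yl in place of ureido on an aromatic carbon. In plain terms, the ureido group, which carries two hydrogen-bond donors, is replaced by a closed succinimide ring that carries none, directly on the shared core.

Among the compounds with values here, no measured step touches this position, so the recorded data give no guide to the size or direction of the change. The expectation therefore rests on the similarity of the remaining structure: compound 4 is expected to give about 6000 nM in this assay, within a range from 2000 nM to 20000 nM, corresponding to an estimated 1.5-fold higher number from compound 2 to compound 4 (0.17 log units; within the scatter).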

Compound 4, half-maximal inhibitory concentration: 4560 nM
The estimate for compound 4 lay 1.3-fold (0.12 log units) above the measured number; low and high end bracket the measured number.
By their numbers in this assay, from the lowest: compounds 2, 1, 3 and 4 (each within the scatter of the next).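

Going by these compounds alone, this is the first step at the aromatic carbon that carries ureido in compound 2, and in this assay it reads a 1.1-fold higher number from compound 2 to compound 4 (0.05 log units; within the scatter). On paper the exchange is substantial: open ureido, with 2 hydrogen-bond donors, gives way to 2,5-dioxopyrrolidin-1-yl, a five-membered non-aromatic ring with 0 hydrogen-bond donors and more heavy atoms, yet the two compounds cannot be told apart, so in this pair the result does not depend on keeping ureido or its donors at this position. Nothing measured here explains why the number holds through this exchange.

As far as these compounds go, this rests on one pair with 1,3-thiazol-2-yl on the sulfonamide nitrogen, so it remains open whether the same exchange would also leave the number in place with the pyridin-2-yl of compound 3. Also open, from the compounds shown here alone, is whether any group on this carbon can move the number beyond the scatter, for instance a free amine, an acetamide or a longer alkyl chain.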